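The compounds below may be only part of what the source reports. "The series", "measured", "known", "first", "only" and "open" are said of these compounds alone.

Measured in a functional assay on HT-1080 cells (Homo sapiens), read by transwell migration, with a stated time of 24 h, tested at 1 uM; on this read-out higher numbers stand for a weaker effect at the one concentration tested and lower numbers for a stronger effect:
compound 1 `CC(=O)OCc1ccc2oc(=O)c(C(=O)Oc3cccc(Cl)c3)cc2c1` gives 49.1%;
compound 2 `CC(=O)OCc1ccc2oc(=O)c(C(=O)Oc3cccc(Br)c3)cc2c1` gives 21.8%;
compound 3 `CC(=O)OCc1ccc2oc(=O)c(C(=O)N(C)c3cccc(Cl)c3)cc2c1` gives 82.6%.

Compound 2 stands lowest of the three, with a number 27.3 percentage points lower from compound 1 to compound 2 (beyond the scatter) and a number 60.8 percentage points higher from compound 2 to compound 3 (beyond the scatter), both beyond the scatter. Compound 4 `CCC(=O)OCc1ccc2oc(=O)c(C(=O)Oc3cccc(Br)c3)cc2c1` differs from compound 2 by methyl in place of hydrogen on a saturated chain carbon bound to a carbonyl carbon, that is acetyl to propanoyl. The measured steps concern other parts of the molecule: a number 27.3 percentage points lower from compound 1 to compound 2 (beyond the scatter) changes the halogen, and a number 33.5 percentage points higher from compound 1 to compound 3 (beyond the scatter) and a number 60.8 percentage points higher from compound 2 to compound 3 (beyond the scatter) change the link at the carbonyl carbon. None of them touches the acetyl group, so they give no direct guidance for this step. Compound 4 is therefore expected to stay near compound 2, with a step of a number 3.2 percentage points higher from compound 2 to compound 4 (within the scatter), not beyond the scatter. The estimate for compound 4 is 25%, in a range from 8% to 50%.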

Compound 4, a percentage reported as activity, at one concentration (the size of the read-out at that concentration, not a potency): 40.2%
Beside the measured number, compound 4's estimate is 15.2 percentage points below it, within the range that was stated.
By their numbers in this assay, from the lowest: compound 2; then compounds 4 and 1 (each within the scatter of the next); then compound 3.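

In this assay the change from acetyl to propanoyl is not silent: the result shows a number 18.4 percentage points higher from compound 2 to compound 4 (beyond the scatter) and so moves the read-out towards a weaker effect at the one concentration tested. The acetoxy end of the molecule therefore bears on the read-out, as the halogen and the link at the carbonyl carbon already did. Nothing measured here accounts for this step.

As far as these compounds go, whether a longer chain such as butanoyl would continue this shift stays open. So does whether a hydroxyl in place of the acetoxy group would restore or lessen the effect.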